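The source may report more compounds than this note shows. Statements on the series, on what has been measured and on what is new or still open speak of the compounds shown alone.

Of the compounds shown here, three sharing the same core have been measured in a physicochemical assay for solubility, using the shake flask method, in simulated intestinal fluid, measured as kinetic solubility, with a stated time of 20 h, at pH 6.5; on this read-out lower numbers stand for lower solubility and higher numbers for higher solubility. Compound 1 `Fc1ccc(-c2nc3cnc(Nc4ccccn4)cc3[nH]2)cc1C(F)(F)F` gives >= 50000 nM, which is a limit of the assay rather than a number. Compound 2 `Fc1ccc(Nc2cc3[nH]c(-c4cccc(C(F)(F)F)c4)nc3cn2)nc1` likewise gives >= 50000 nM, again a limit. Compound 3 `Fc1cnc(Nc2cc3[nH]c(-c4cccc(C(F)(F)F)c4)nc3cn2)c(F)c1` gives >= 50000 nM, also a limit. Among the measured compounds shown here, the only single-point step among them, a step that the two limits leave unreadable from compound 2 to compound 3, has a limit at both ends and so yields no size. Compound 3 thus stands at the edge of what this assay can report, level with the two others, with no number to set it apart.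

Compound 4 `N#Cc1ccc(Nc2cc3[nH]c(-c4cccc(C(F)(F)F)c4)nc3cn2)nc1` is not yet measured; it differs from compound 3 by 5-cyanopyridin-2-yl in place of 3,5-difluoropyridin-2-yl on a nitrogen on an aromatic ring. No measured step covers a change of this kind, and the one step shown, a step that the two limits leave unreadable from compound 2 to compound 3, gives no size to lean on. What the data do show is the limit of >= 50000 nM in this assay, at which 3 of the 3 values shown sit, and that is the whole of the evidence. Compound 4 is therefore expected to sit near that same limit, with a number no higher from compound 3 to compound 4 (the limit leaves the size open) as the expected step. The estimate for compound 4 is 50000 nM, in the range 15000 nM to 150000 nM.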

Compound 4, solubility: >= 50000 nM
Compound 4: only a limit was reported (the forecaster's own chance of this, stated with the estimate: 70%); the middle value lies on the limit itself.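

Compound 4 gives only a limit in this assay, as do compound 2 and compound 3, so neither new step to compound 4 can be read: the limit of >= 50000 nM in this assay, at which 4 of the 4 values shown sit. From the compounds shown here alone, whether these compounds differ in solubility at all, and by how much, stays open.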